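This account rests on a few compounds, and the source may have more. Where it says the series, first, only, none or still open, it means among the compounds named here.

Measured so far:
Compound 1, `Cc1nccc2nn(-c3ccccc3)cc12`. In a functional assay on K562 cells (Homo sapiens) for inhibition, read by fluorescence, with a stated time of 72 h (a higher number here means a weaker inhibitor of growth, a lower number a stronger inhibitor of growth), compound 1 gives > 100000 nM, which is a limit of the assay and not a number.
Compound 2, `c1ccc(-c2cc3nn(-c4ccccc4)cc3cn2)cc1`. In this assay compound 2 gives 3400 nM.

Compound 2 is the only one of the two with a number in this assay; the other value is a limit, as the limit of > 100000 nM in this assay, at which 1 of the 2 values shown sits, records. Among the compounds with values here, compound 1 and compound 2 differ from each other in two places, so their values say nothing about any single change, and no step between measured compounds is available.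

Compound 3, `Cc1nc(-c2ccccc2)cc2nn(-c3ccccc3)cc12`, is not yet measured. It differs from compound 2 by methyl in place of hydrogen on an aromatic carbon. Compound 3 carries both the phenyl group of compound 2 and the methyl group of compound 1. Within the data shown here, no measured step shows what this methyl group does on its own, so the size of the step from compound 2 to compound 3 in this assay is uncertain; a small change, not clearly beyond the scatter, is expected, with a slight lean toward weaker growth inhibition. On that basis compound 3 is estimated to give 5000 nM in this assay, with a range from 1500 nM to 25000 nM, which corresponds to an expected step of a 1.5-fold higher number from compound 2 to compound 3 (0.17 log units; within the scatter).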

Compound 3, concentration for 50% growth inhibition: 6300 nM
Compound 3: middle estimate off by 1.3-fold (0.10 log units), on the low side; measured number inside the range.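

The methyl group can now be read on its own: on the aromatic carbon next to the ring nitrogen, with the phenyl group in place, it gives in this assay a 1.9-fold higher number from compound 2 to compound 3 (0.27 log units; within the scatter) and so leaves growth inhibition unchanged within the scatter. The phenyl group can also be read on its own with the methyl group present, and it gives an at least 15-fold lower number from compound 1 to compound 3 (1.20 log units; beyond the scatter), so among the compounds shown the large step belongs to the phenyl group and not to the methyl group. Compound 1 gives > 100000 nM, which is a limit of the assay and not a number, so the large step has a lower bound but no exact size: the limit of > 100000 nM in this assay, at which 1 of the 3 values shown sits.

The compounds shown leave open whether the aromatic carbon next to the ring nitrogen would accept something other than methyl, such as an amine, a methoxy group or a longer chain, with so little change. They also leave open how far the phenyl group itself can be altered, for instance by a carboxylic acid or a fluorine on its ring, without losing the growth inhibition seen in compound 2 and compound 3.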